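A few compounds are considered here, and "the series" means these few. Any claim that something is new, unique, unknown or untested is made for them only; others in the source may bear on it.

Compound 1 `O=C1NCCN1c1ccc(S(=O)(=O)Nc2ccc(C3CCCCC3)cc2)cc1` in a functional assay on HT-29 cells (Homo sapiens) for antiproliferative activity, read by sulforhodamine B assay, with a stated time of 48 h (on this read-out higher numbers stand for weaker inhibition and lower numbers for stronger inhibition), gives > 1000 nM; this value is a limit of the assay, not a number.
Compound 2 `CCc1cccc(NS(=O)(=O)c2ccc(N3CCNC3=O)cc2)c1` in this assay gives 110 nM.
Compound 3 `CCCCCc1ccc(NS(=O)(=O)c2ccc(N3CCNC3=O)cc2)cc1` in this assay gives 990 nM.

Among the two numbers recorded, compound 2 stands lowest, and its nearest neighbour compound 3 sits a good deal higher, a gap beyond the usual scatter. The third entry, that of compound 1, is only a limit of > 1000 nM in this assay, at which 1 of the 3 values shown sits, and so gives no size of its own. Among the measured compounds shown here, the one step that can be read between measured compounds, a number no higher from compound 1 to compound 3 (the limit leaves the size open), runs from a limit and its size stays open.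

The unmeasured compound 4 `COc1ccccc1NS(=O)(=O)c1ccc(N2CCNC2=O)cc1` differs from compound 2 in one place: 2-methoxyphenyl in place of 3-ethylphenyl on a sulfonamide nitrogen. For the measured compounds named here, none of the measured steps covers this kind of change, since the only step recorded alters a group on an aromatic carbon, not the aryl on the sulfonamide nitrogen. What the numbers do show is that compound 2, with 3-ethylphenyl, sits lowest, and that compound 3, carrying a longer pentyl chain, is clearly weaker. Going by the values given here, with the 2-methoxyphenyl group there is thus no direct precedent, and the estimate is correspondingly wide. Compound 4 is expected to land somewhat weaker than compound 2, by a step of about a 3.2-fold higher number from compound 2 to compound 4 (0.50 log units; beyond the scatter), giving an estimated value of 350 nM, with a range from 90 nM to 1500 nM.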

Compound 4, half-maximal inhibitory concentration: 550 nM
Compound 4: the middle estimate sits 1.6-fold (0.20 log units) below what was measured; measured number inside the range.
By their numbers in this assay, from the lowest: compound 2; then compounds 4 and 3 (each within the scatter of the next). At a limit, above all of these: compound 1.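

In this assay, among the compounds shown here, the change of 2-methoxyphenyl in place of 3-ethylphenyl on the sulfonamide nitrogen gives the first readable step at this place, a 5.0-fold higher number from compound 2 to compound 4 (0.70 log units; beyond the scatter). The two groups carry the same count of heavy atoms, and the entering group holds one hydrogen-bond acceptor where the leaving group holds none, so a change that leaves the heavy-atom count untouched is still enough to move the number beyond the scatter. Compound 4 and compound 3 lie within the scatter of each other, so no order can be drawn between them, even though they carry different groups on that nitrogen.

Why the number moves stays open, since nothing given here bears on the cause of this step. Going by these compounds, it also stays open whether the step follows the methoxy group itself or the place it holds on the aryl ring, and how an amine, a carboxylic acid or a longer alkoxy chain on that ring would read in this assay.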